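The source may hold more compounds than are shown below. What is called first, only, known or untested is meant among the compounds shown, and "the series" means these compounds.

Of the compounds shown here, two have numbers so far in a functional assay on HeLa cells (Homo sapiens) for inhibition; a higher number here means a weaker inhibitor, a lower number a stronger inhibitor. Compound 1 (`O=C/C=C/n1c(=O)c(I)cn([C@H]2C[C@H](O)[C@@H](CO)O2)c1=O`) gives 20 uM, the lower of the two numbers and so the stronger inhibitor. Compound 2 (`Cc1cn([C@H]2C[C@H](O)[C@@H](CO)O2)c(=O)n(/C=C/CO)c1=O`) gives 60 uM, and that gap lies beyond the usual scatter.

The next compound, still to be measured in this assay, is compound 3 (`O=C/C=C/n1c(=O)ccn([C@H]2C[C@H](O)[C@@H](CO)O2)c1=O`). Going from compound 1 to compound 3, the change is hydrogen in place of iodo on an aromatic carbon, while the 2-formylethenyl group stays.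

Among the compounds with values here, no two measured compounds differ in one place only, so the series offers no direct measure of this change. The only reference carrying the 2-formylethenyl group is compound 1 at 20 uM, and the expectation starts there. A modest move towards a higher number, meaning a weaker inhibitor, is expected, though a result within the scatter would fit as well. The estimated step is a 1.8-fold higher number from compound 1 to compound 3 (0.24 log units; within the scatter). The expected value for compound 3 is 35 uM, with an estimated range from 12 uM to 100 uM.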

Compound 3, concentration for 50% inhibition: 1 uM
Compound 3: middle estimate off by 35-fold (1.54 log units), on the high side; the measured number lies below the stated range.
By their numbers in this assay, from the lowest: compound 3; then compound 1; then compound 2.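

In this assay, within the data shown here, this is the first direct reading at this position: hydrogen in place of iodo on an aromatic carbon, ortho to a group of 1 heavy atom and meta to a 2-formylethenyl group, gives a 20-fold lower number from compound 1 to compound 3 (1.30 log units; beyond the scatter) and so a clearly stronger inhibitor. With the 2-formylethenyl group unchanged, the read-out is therefore sensitive to what sits at this position, and of the two substituents compared there, hydrogen goes with the stronger inhibition. Nothing among the data shown accounts for the size of this step.

Hydrogen and iodo are the only pair read at this position with the 2-formylethenyl group in place, so it remains open whether fluoro or an amine there would stay close to hydrogen or fall towards iodo. On these data alone, it is also open whether the same step would appear if a carboxylic acid or a longer chain replaced the 2-formylethenyl group, since one pair cannot show whether the effect of the iodo group depends on that group.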